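This account rests on a few compounds, and the source may have more. Where it says the series, first, only, none or still open, it means among the compounds named here.

Compound 1 `CN1CCN(C[C@H]2CN(c3ccc(-n4cc(-c5ccccn5)cn4)c(F)c3)C(=O)O2)CC1`: 70 ug/mL in an ADME assay on HEK293-A cells (Homo sapiens) for cytotoxicity, read by MTT assay, with a stated time of 48 h; a lower number here means a stronger inhibitor, a higher number a weaker inhibitor
Compound 2 `O=C1CSC(=O)N1C[C@H]1CN(c2ccc(-n3cc(-c4ccccn4)cn3)c(F)c2)C(=O)O1`: 283 ug/mL in this assay

Compound 2 stands highest of the two numbers; compound 1 lies a 4.0-fold higher number from compound 1 to compound 2 (0.61 log units; beyond the scatter) away. Compound 3 `O=C(OC[C@H]1CN(c2ccc(-n3cc(-c4ccccn4)cn3)c(F)c2)C(=O)O1)c1ccccc1` differs from compound 2 by benzoyloxy in place of 2,4-dioxo-1,3-thiazolidin-3-yl on a saturated chain carbon bound to a saturated ring carbon. Within the data shown here, the only measured step, a 4.0-fold higher number from compound 1 to compound 2 (0.61 log units; beyond the scatter), changed the same position but swapped in a different group, so it bears only loosely on this change; it shows that altering this group can shift the number beyond the scatter. A modest downward step, a 1.9-fold lower number from compound 2 to compound 3 (0.28 log units; within the scatter), is therefore expected. The estimate for compound 3 is 150 ug/mL, with a range from 60 ug/mL to 400 ug/mL.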

Compound 3, half-maximal inhibitory concentration: > 400 ug/mL
Compound 3: only a limit was reported (the forecaster's own chance of this, stated with the estimate: 5%); at least 2.6-fold (0.42 log units) between middle value and limit.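

Compound 3 gives only a limit, not a number, in this assay: the limit of > 400 ug/mL in this assay, at which 1 of the 3 values shown sits.
Replacing 4-methylpiperazin-1-yl with benzoyloxy gives a clear change (an at least 5.7-fold higher number from compound 1 to compound 3 (0.75 log units; beyond the scatter)) so a second group at this place also separates from compound 1. Replacing 2,4-dioxo-1,3-thiazolidin-3-yl with benzoyloxy gives only a floor (an at least 1.4-fold higher number from compound 2 to compound 3 (0.15 log units; that floor lies within the scatter)) so these two groups cannot be placed in order.

From the compounds shown here alone, how far compound 3 truly lies from compound 2 stays open. So does whether a simple hydroxyl, a carboxylic acid or an open-chain amine at this place would follow compound 1 or compound 3.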